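A Hydroxyethyl Group in Place of Cyclopropyl

The compounds below may be only part of what the source reports. "The series", "measured", "known", "first", "only" and "open" are said of these compounds alone.

Compound 1 `O=C1O/C(=C\Cn2cc(-c3ccc(Br)cc3)nn2)C(OCc2ccccc2)=C1OCc1ccccc1` and compound 2 `O=C1O[C@H]([C@@H](O)Cn2cc(C3CC3)nn2)C(OCc2ccccc2)=C1OCc1ccccc1` share a core and differ in the side chain that carries the five-membered aromatic ring with three nitrogen. Within the data shown here, in a functional assay on HepG2 cells (Homo sapiens) for antiproliferative activity, read by MTT assay, with a stated time of 72 h (a lower number here means a stronger inhibitor, a higher number a weaker inhibitor), compound 2 gives 38100 nM, which is the only actual number measured in this small set. For compound 1 the result is only a limit, > 100000 nM, as the limit of > 100000 nM in this assay, at which 1 of the 2 values shown sits, records. Compound 2 therefore stands as the single measured point from which anything further can be judged.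

Compound 3 `O=C1O[C@H]([C@@H](O)Cn2cc(CCO)nn2)C(OCc2ccccc2)=C1OCc1ccccc1` carries 2-hydroxyethyl in place of cyclopropyl on an aromatic carbon. Among the measured compounds shown here, no measured pair in this set differs in just one place, so the size of this step has no direct precedent here. The change from compound 2 to compound 3 is expected to be small, a 1.2-fold higher number from compound 2 to compound 3 (0.07 log units; within the scatter), staying within the usual scatter. Compound 3 is estimated at 45000 nM, with a likely range from 15000 nM to 100000 nM.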

Compound 3, half-maximal inhibitory concentration: 68100 nM
Beside the measured number, compound 3's estimate is 1.5-fold (0.18 log units) below it, within the range that was stated.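

Placing 2-hydroxyethyl in place of cyclopropyl on this aromatic carbon gives, in this assay, a 1.8-fold higher number from compound 2 to compound 3 (0.25 log units; within the scatter), so the two compounds cannot be told apart here. Among these compounds, this is the first one-place comparison at this position, and it shows that a ring of carbon alone and an open chain with a hydrogen-bond donor and acceptor, both of the same heavy-atom count, give readings that lie within the scatter of each other. These readings lie in a weak part of the scale, which has an end: the limit of > 100000 nM in this assay, at which 1 of the 3 values shown sits.

Going by these compounds, whether an amine, a carboxylic acid or a longer chain at this carbon would give a step beyond the scatter remains open. Also open, on these data alone, is whether a phenyl ring here, on the same side chain as in compound 2, would read any differently.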